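Series notes: hydrogen to chloro step, compound 3 to compound 4

The source may hold more compounds than are shown below. What is called first, only, known or untested is meant among the compounds shown, and "the series" means these compounds.

Compound 1 `COC(=O)c1cc(-c2csc(N/N=C/c3ccc(Cl)cc3Cl)n2)ccc1OCc1ccccc1` — 56.1%
Compound 2 `Fc1ccc(-c2csc(N/N=C/c3cccs3)n2)cc1` — 97%
Compound 3 `Clc1ccc(/C=N/Nc2nc(-c3ccccc3)cs2)c(Cl)c1` — 95.8%

In a functional assay, read by spectrophotometry, with a stated time of 15 min, tested at 100 ug/mL (on this read-out lower numbers stand for a weaker effect and higher numbers for a stronger effect at the one concentration tested), compound 3 gives 95.8%, second highest of the three numbers; compound 2 gives 97%, within the scatter of it, while compound 1 gives 56.1%, a gap beyond the scatter. Compound 4 `Clc1ccc(-c2csc(N/N=C/c3ccc(Cl)cc3Cl)n2)cc1` is not yet measured. It differs from compound 3 by chloro in place of hydrogen on an aromatic carbon. Within the data shown here, no measured pair shows this change, so its size is unknown from these data; given that compound 3 already sits at 95.8%, a step no larger than the scatter is expected, in either direction. The estimate for compound 4 in this assay is 93%, range 78% to 99%, meaning an expected step of a number 2.8 percentage points lower from compound 3 to compound 4 (within the scatter) that stays within the scatter.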

Compound 4, a percentage reported as inhibition, at one concentration (the size of the read-out at that concentration, not a potency): 92.4%
Compound 4: the middle estimate sits 0.6 percentage points above what was measured; the range from low to high includes it.
By their numbers in this assay, from the lowest: compound 1; then compounds 4, 3 and 2 (each within the scatter of the next).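

In this assay, among these compounds, the phenyl to 4-chlorophenyl change gives a number 3.4 percentage points lower from compound 3 to compound 4 (within the scatter) and is the first reading of chloro in place of hydrogen on this aromatic carbon, para to a large group. The position accepts chloro without a step beyond the scatter, though compound 3 leaves the read-out little room for any gain. No measurement bears on the reason for this step. As far as these compounds go, whether an amine or a carboxylic acid at this position would keep the effect remains open. A single concentration also leaves potency unresolved.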